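Trading a methoxy group for hydrogen on compound 3

A few compounds are considered here, and "the series" means these few. Any claim that something is new, unique, unknown or untested is made for them only; others in the source may bear on it.

Of the compounds shown here, three built on one shared core have numbers so far in a functional assay on HeLa cells (Homo sapiens) for antiproliferative activity, read by spectrophotometry, with a stated time of 2 days; on this read-out higher numbers stand for weaker inhibition of growth and lower numbers for stronger inhibition of growth. Compound 1 `Cc1cc(F)ccc1Nc1ncc(C(F)(F)F)c(N2Cc3cccc(N(C)S(C)(=O)=O)c3C2)n1` gives 6500 nM. Compound 2 `CN(c1cccc2c1CN(c1nc(Nc3cc(C(F)(F)F)cc(C(F)(F)F)c3)ncc1C(F)(F)F)C2)S(C)(=O)=O` gives 9200 nM. Compound 3 `COc1cc(Nc2ncc(C(F)(F)F)c(N3Cc4cccc(N(C)S(C)(=O)=O)c4C3)n2)cc(C(F)(F)F)c1` gives 5100 nM. Compound 3 therefore stands level with the other two, since its steps to both lie within the scatter of repeated measurements.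

Compound 4 `CN(c1cccc2c1CN(c1nc(Nc3cccc(C(F)(F)F)c3)ncc1C(F)(F)F)C2)S(C)(=O)=O` has not been measured. It carries hydrogen in place of methoxy on an aromatic carbon of compound 3, meta to a trifluoromethyl group: hydrogen in place of methoxy on an aromatic carbon. The aryl group thus goes from 3-methoxy-5-(trifluoromethyl)phenyl to 3-(trifluoromethyl)phenyl.

For the measured compounds named here, two measured steps bear on this change. The closest swaps a group on the same carbon, with methoxy in place of trifluoromethyl, and it amounts to a 1.8-fold lower number from compound 2 to compound 3 (0.26 log units; within the scatter). The other replaces the whole aryl group and amounts to a 1.3-fold lower number from compound 1 to compound 3 (0.11 log units; within the scatter). Going by the values given here, neither step leaves the scatter, although no measured compound yet has hydrogen on this carbon, so the evidence is indirect. No change beyond the scatter is therefore expected in this assay. The expected step is a 1.2-fold higher number from compound 3 to compound 4 (0.07 log units; within the scatter). Compound 4 is estimated at 6000 nM, with an expected range from 2500 nM to 14000 nM.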

Compound 4, concentration for 50% growth inhibition: 5300 nM
Compound 4: the middle estimate sits 1.1-fold (0.05 log units) above what was measured; the measured number falls inside the stated range.
By their numbers in this assay, from the lowest: compounds 3, 4, 1 and 2 (each within the scatter of the next).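

Compound 4 is the first compound shown with hydrogen on this aromatic carbon, and in this assay losing the methoxy group leaves no change that can be told apart from the scatter (a 1.0-fold higher number from compound 3 to compound 4 (0.02 log units; within the scatter)). Hydrogen also stands level with trifluoromethyl on the same carbon (a 1.7-fold lower number from compound 2 to compound 4 (0.24 log units; within the scatter)), so hydrogen, methoxy and trifluoromethyl at this place all lie within the scatter of one another, and the ring needs no second group here to keep its number. Against the differently substituted aryl group of compound 1, the 3-(trifluoromethyl)phenyl group also stays level (a 1.2-fold lower number from compound 1 to compound 4 (0.09 log units; within the scatter)), which leaves all four compounds without a step beyond the scatter.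

Still open, from the compounds shown here alone, is whether a more different group on this carbon, such as an amine, a carboxylic acid or a longer chain, would move the number beyond the scatter in this assay or leave it level as these three groups do. Nothing measured here accounts for why hydrogen, methoxy and trifluoromethyl read alike at this place.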